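The source may report more compounds than this note shows. Statements on the series, on what has been measured and on what is new or still open speak of the compounds shown alone.

Working notes on the series. For the measured compounds named here, compound 2 `Cn1nncc1-c1cc(-c2ccc(C(N)=O)cc2)cc(-c2ccc(C#N)cc2)n1` is one of two compounds measured in a physicochemical assay for solubility, at pH 6; a higher number here means a more soluble compound, a lower number a less soluble compound; compound 2 gives 32000 nM, the lower of the two numbers, with compound 1 `N#Cc1ccc(-c2cc(-c3ccc(C(N)=O)cc3)cc(-c3cncs3)n2)cc1` nearest at 64000 nM. Going by the values given here, the only step between measured compounds runs a 2.0-fold lower number from compound 1 to compound 2 (0.30 log units; within the scatter), a swap of one five-membered aromatic ring with hetero atoms for another.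

Compound 3 `N#Cc1ccc(-c2cc(-c3ccc(C(N)=O)cc3)cc(-c3cccc(F)c3)n2)cc1` is not yet measured. Compared with compound 2, (3-fluorophenyl in place of 1-methyl-1H-1,2,3-triazol-5-yl on an aromatic carbon). Among the compounds with values here, no measured step covers a change from a five-membered ring with hetero atoms to a six-membered ring of carbon only, so the step from compound 1 to compound 2 bears on it only loosely: it shows that exchanging one azole for another moved this assay little. Because compound 2 gives 32000 nM, already the lower of the two numbers, and the entering ring carries no hydrogen-bond acceptors, a drop beyond the scatter is expected for compound 3. For compound 3 the estimate is a 4.0-fold lower number from compound 2 to compound 3 (0.60 log units; beyond the scatter), giving 8000 nM with a range from 2000 nM to 32000 nM.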

Compound 3, solubility: 2000 nM
For compound 3 the middle estimate is 4.0-fold (0.60 log units) above the measured one; low and high end bracket the measured number.
By their numbers in this assay, from the lowest: compound 3; then compounds 2 and 1 (each within the scatter of the next).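

In this assay, the position on an aromatic carbon next to the ring nitrogen proves sensitive to the group it carries: 3-fluorophenyl in place of 1-methyl-1H-1,2,3-triazol-5-yl gives a 16-fold lower number from compound 2 to compound 3 (1.20 log units; beyond the scatter), and 3-fluorophenyl in place of 1,3-thiazol-5-yl gives a 32-fold lower number from compound 1 to compound 3 (1.51 log units; beyond the scatter). Both steps lie beyond the scatter, whereas the exchange of one five-membered ring for the other stays within it, so among these three compounds the large change comes only with the six-membered ring of carbon only. No measurement on hand gives a reason for this drop.

Ring size, ring hetero atoms and the fluorine all change together in these steps, so their separate contributions stay open. Also open, as far as these compounds go, is how a plain phenyl, a pyridine ring, or a phenyl ring carrying an amine or a carboxylic acid would read at this position.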